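Swapping the Ring Tail: Expected Free Fraction

The source may report more compounds than this note shows. Statements on the series, on what has been measured and on what is new or still open speak of the compounds shown alone.

Compound 1 `NC(=O)[C@@H]1CC[C@H](c2ccc(OCc3ccc(F)cc3)cc2)N1` gives "not determined" (no result reported) in an ADME assay on a cell-free system (plasma, Rattus norvegicus) for protein binding (on this read-out higher numbers stand for a larger free fraction and lower numbers for a smaller free fraction), so no number says where it stands. Its close relative compound 2 `NC(=O)[C@@H]1CC[C@H](c2ccc(Oc3ccc(F)cc3)cc2)N1` gives 0.11 in this assay, the only measured point here, and without a shown step between compound 1 and compound 2, compound 1 remains unplaced. Compound 3 `N#Cc1ccccc1COc1ccc([C@H]2CC[C@@H](C(N)=O)N2)cc1` differs from compound 1 by 2-cyanophenyl in place of 4-fluorophenyl on a saturated chain carbon bound to an oxygen on an aromatic ring. Among the measured compounds shown here, with no measured step to lean on, only a small rise in free fraction is expected, possibly no larger than the usual scatter. For compound 3 the expected value in this assay is 0.15, ranging from 0.06 to 0.35.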

Compound 3, unbound fraction: 0.12
For compound 3 the middle estimate is 1.3-fold (0.10 log units) above the measured one; measured number inside the range.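

No step from compound 1 to compound 3 can be read in this assay, and nothing shown accounts for the value of compound 3. As far as these compounds go, what replacing 4-fluorophenyl with 2-cyanophenyl does to the free fraction remains open.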